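A few compounds are considered here, and "the series" means these few. Any claim that something is new, unique, unknown or untested is made for them only; others in the source may bear on it.

Compound 1 `COc1ccc(C2=C(c3ccc(SC)cc3)CC3CCCN3C2=O)cc1Br` gives 3000 nM in a functional assay on M14 cells (Homo sapiens) for cytotoxicity (a lower number here means a stronger inhibitor of growth, a higher number a weaker inhibitor of growth), the second highest of the three numbers; compound 3 `CSc1ccc(C2=C(c3ccc(C)cc3)C(=O)N3CCCC3C2)cc1` gives 6000 nM, a step of a 2.0-fold higher number from compound 1 to compound 3 (0.30 log units; within the scatter), while compound 2 `CSc1ccc(C2=C(c3ccc(OCC4CO4)cc3)C(=O)N3CCCC3C2)cc1` gives 90 nM, far below it. Compound 4 `CSc1ccc(C2=C(c3ccc(SC)cc3)C(=O)N3CCCC3C2)cc1` differs from compound 1 in one place: 4-(methylsulfanyl)phenyl in place of 3-bromo-4-methoxyphenyl on a double-bonded ring carbon. The step that bears on this is the one at the same ring carbon, a 2.0-fold higher number from compound 1 to compound 3 (0.30 log units; within the scatter), which stayed within the scatter; the large step of a 67-fold higher number from compound 2 to compound 3 (1.82 log units; beyond the scatter) concerns a different position and does not guide it. The replacement of the same group is therefore expected to give no change beyond the scatter, no change at the digits printed from compound 1 to compound 4 (within the scatter). Compound 4 is estimated at 3000 nM, within 1000 nM to 10000 nM.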

Compound 4, concentration for 50% growth inhibition: 5000 nM
For compound 4 the middle estimate is 1.7-fold (0.22 log units) below the measured one; low and high end bracket the measured number.
By their numbers in this assay, from the lowest: compound 2; then compounds 1, 4 and 3 (each within the scatter of the next).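

In this assay, 4-(methylsulfanyl)phenyl in place of 3-bromo-4-methoxyphenyl on the double-bonded ring carbon gives a step within the scatter (a 1.7-fold higher number from compound 1 to compound 4 (0.22 log units; within the scatter)), and methylsulfanyl in place of methyl on the aromatic carbon does too (a 1.2-fold lower number from compound 3 to compound 4 (0.08 log units; within the scatter)). Methylsulfanyl in place of (oxiran-2-yl)methoxy gives a large step (a 56-fold higher number from compound 2 to compound 4 (1.74 log units; beyond the scatter)), so compound 2 now stands apart from a second close partner. Nothing measured here explains these results.

The compounds shown leave open whether a group such as an amine or a longer chain on that aromatic carbon would match (oxiran-2-yl)methoxy. They also leave open whether any replacement on the double-bonded ring carbon gives a step beyond the scatter.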